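The source may hold more compounds than are shown below. What is called first, only, known or untested is meant among the compounds shown, and "the series" means these compounds.

The series shares one core, seen in compound 1 `COc1cc(-c2cc(-c3ccc(Cl)cc3)nc(-c3ccccc3)n2)cc(OC)c1OC`, compound 2 `COc1cc(-c2cc(-c3cccc([N+](=O)[O-])c3)nc(-c3ccccc3)n2)cc(OC)c1OC` and compound 3 `COc1cc(-c2cc(-c3ccc(C)cc3)nc(-c3ccccc3)n2)cc(OC)c1OC`, each differing from the next in a single place. In a functional assay on MDA-MB-231 cells (Homo sapiens) for inhibition, read by MTT assay, with a stated time of 48 h (on this read-out higher numbers stand for weaker inhibition and lower numbers for stronger inhibition), compound 1 gives > 25000 nM, which is the limit of > 25000 nM in this assay, at which 1 of the 3 values shown sits, and not a number. In this assay compound 2 gives 2440 nM. In this assay compound 3 gives 5110 nM. Of the two numbers shown, compound 2 holds the lowest, with compound 3 nearest at a 2.1-fold higher number from compound 2 to compound 3 (0.32 log units; beyond the scatter). For the measured compounds named here, the other steps read an at least 10-fold lower number from compound 1 to compound 2 (1.01 log units; beyond the scatter) and an at least 4.8-fold lower number from compound 1 to compound 3 (0.68 log units; beyond the scatter), so the 3-nitrophenyl group gives the lowest number of the three so far.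

Compound 4 `COc1cc(-c2cc(-c3cccc(O)c3)nc(-c3ccccc3)n2)cc(OC)c1OC` is not yet measured. It differs from compound 2 in one place: hydroxy in place of nitro on an aromatic carbon. Going by the values given here, no measured step exchanges nitro for hydroxy, so the steps in hand bear on it only by showing that the three groups tried spread widely, from the limit of compound 1 to the number of compound 2. A modest rise in number, beyond the scatter, is expected. Compound 4 is therefore estimated at 5000 nM, within 1500 nM to 20000 nM, in this assay. The expected step is a 2.0-fold higher number from compound 2 to compound 4 (0.31 log units; beyond the scatter).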

Compound 4, half-maximal inhibitory concentration: 1990 nM
Compound 4: the middle estimate sits 2.5-fold (0.40 log units) above what was measured; measured number inside the range.
By their numbers in this assay, from the lowest: compounds 4 and 2 (each within the scatter of the next); then compound 3. At a limit, above all of these: compound 1.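

Hydroxy in place of nitro on this aromatic carbon gives a 1.2-fold lower number from compound 2 to compound 4 (0.09 log units; within the scatter) in this assay, so within this pair the read-out does not separate the two groups. The 3-hydroxyphenyl group also gives a 2.6-fold lower number from compound 3 to compound 4 (0.41 log units; beyond the scatter) and an at least 12-fold lower number from compound 1 to compound 4 (1.09 log units; beyond the scatter), which places it, like 3-nitrophenyl, apart from both 4-methylphenyl and 4-chlorophenyl among these four compounds, with no compound shown going against this. The last of these steps rests on a limit and not a number, the value of compound 1: the limit of > 25000 nM in this assay, at which 1 of the 4 values shown sits.

Open, on these data alone, is whether that gap follows the group or its place on the ring, as the steps from 4-methylphenyl and 4-chlorophenyl change both at once. Also open, as far as these compounds go, is how an amine or a carboxylic acid would read on the same aromatic carbon.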